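The source may hold more compounds than are shown below. What is called first, only, known or untested is meant among the compounds shown, and "the series" means these compounds.

Measured compounds:
compound 1, `S=c1n(-c2ccc(Cl)cc2)c(=S)n2n1CCCC2`: 43.7 nM
compound 2, `S=c1n(-c2ccccc2)c(=S)n2n1CCCC2`: 6310 nM
compound 3, `S=c1s/c(=N\c2ccc(Cl)cc2)n2n1CCCC2`: 234 nM

All three were tested in a functional assay on the whole organism with Scenedesmus acutus as the target, read by spectrophotometry; on this read-out lower numbers stand for stronger inhibition and higher numbers for weaker inhibition. Compound 1 and compound 2 share one core and differ in a single place: hydrogen in place of chloro on an aromatic carbon. That change produced a 140-fold higher number from compound 1 to compound 2 (2.16 log units; beyond the scatter), so the loss of the chloro group weakened the compound considerably. Compound 3 is built from the same atoms as compound 1, joined differently; the difference between the two cores is not broken down here. In this assay compound 3 lies between the other two: weaker than compound 1 and stronger than compound 2, both gaps beyond the usual scatter.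

Compound 4, `S=c1s/c(=N\c2ccccc2)n2n1CCCC2`, has not been measured. It stands to compound 3 exactly as compound 2 stands to compound 1: hydrogen in place of chloro on an aromatic carbon. The surroundings of the change are described in the same words in both pairs, so this is the same change, recurring among these compounds and measured once so far. A weakening is expected for compound 4 because a 140-fold higher number from compound 1 to compound 2 (2.16 log units; beyond the scatter) shows what this change did on the related core. Since the core of compound 3 is not the core of compound 1, the size of the step is uncertain, and the expected range is kept wide. The step from compound 3 to compound 4 is expected to be a 64-fold higher number from compound 3 to compound 4 (1.81 log units; beyond the scatter). Compound 4 is estimated at 15000 nM, expected to fall between 2500 nM and 80000 nM.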

Compound 4, half-maximal inhibitory concentration: 13800 nM
Beside the measured number, compound 4's estimate is 1.1-fold (0.04 log units) above it; the range from low to high includes it.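

Taking the chloro group off compound 3 and leaving hydrogen in its place gave a 59-fold higher number from compound 3 to compound 4 (1.77 log units; beyond the scatter) in this assay, so this change weakened inhibition on this core just as it did on the core of compound 1. Set side by side, the two steps agree in direction and, given normal assay variation, in size: the same change on two cores in this assay, a 140-fold higher number (2.16 log units; beyond the scatter) from compound 1 to compound 2 and a 59-fold higher number (1.77 log units; beyond the scatter) from compound 3 to compound 4, 2.4-fold (0.39 log units) apart, within the scatter of two such steps This shows that, for these two cores, the effect of the change measured on one core carried over well to the other, but it rests on only two pairs and one change, so it does not show that the same would hold on a third core, nor does it explain why the chloro group matters.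

The compounds shown compare only chloro with hydrogen on an aromatic carbon, para to a large group, so it remains open whether fluoro, bromo, methyl, methoxy or an amine at that place would match the chloro group, fall short of it or surpass it. From the compounds shown here alone, it also remains open whether any such replacement would rank the same way on both cores.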